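The source may report more compounds than this note shows. Statements on the series, on what has been measured and on what is new or still open speak of the compounds shown alone.

Measured compounds:
- Compound 1, `O=C(Nc1cccc(-c2oc3cc(-c4ccc(F)cc4)ccc3c(=O)c2O)c1)c1ccccc1F`, gives 10100 nM in a functional assay on HepG2 cells (Homo sapiens) for antiproliferative activity, read by CCK-8 assay, with a stated time of 72 h; on this read-out lower numbers stand for stronger inhibition and higher numbers for weaker inhibition.
- Compound 2, `O=C(Nc1cccc(-c2oc3cc(-c4ccc(F)cc4)ccc3c(=O)c2O)c1)c1ccc(F)cc1`, gives 9280 nM in this assay.
- Compound 3, `Cc1ccc(C(=O)Nc2cccc(-c3oc4cc(-c5ccc(F)cc5)ccc4c(=O)c3O)c2)cc1`, gives 2320 nM in this assay.

Compound 3 holds the lowest number of the three, and its separation from the others is real: the step of a 4.0-fold lower number from compound 2 to compound 3 (0.60 log units; beyond the scatter) and the step of a 4.4-fold lower number from compound 1 to compound 3 (0.64 log units; beyond the scatter) both lie beyond the scatter, so compound 3 is the strongest inhibitor among the three. Compound 4, `Cc1ccccc1C(=O)Nc1cccc(-c2oc3cc(-c4ccc(F)cc4)ccc3c(=O)c2O)c1`, has not yet been measured. It differs from compound 3 by 2-methylphenyl in place of 4-methylphenyl on a carbonyl carbon.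

Two kinds of measured step bear on this. Among the measured compounds shown here, the step of a 1.1-fold lower number from compound 1 to compound 2 (0.04 log units; within the scatter) is the closest precedent: it moves a fluoro substituent on the same phenyl ring between the same two positions and gives no change beyond the scatter. The steps from compound 1 and compound 2 to compound 3 show that the methyl group itself, not its position, produced the gain seen so far. Taken together, a step of little or no size beyond the scatter is expected, with a slight lean toward a higher number. Compound 4 is therefore expected to give about 3500 nM in this assay, with a range from 1200 nM to 10000 nM. That estimate corresponds to an expected step of a 1.5-fold higher number from compound 3 to compound 4 (0.18 log units; within the scatter).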

Compound 4, half-maximal inhibitory concentration: 19400 nM
For compound 4 the middle estimate is 5.5-fold (0.74 log units) below the measured one; measured number outside the range, above it.
By their numbers in this assay, from the lowest: compound 3; then compounds 2, 1 and 4 (each within the scatter of the next, the first and the last beyond it).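

Unlike the fluoro pair, where a 1.1-fold lower number from compound 1 to compound 2 (0.04 log units; within the scatter) showed no real effect of position, the methyl pair shows that position on this phenyl ring can matter a great deal in this assay: an 8.4-fold higher number from compound 3 to compound 4 (0.92 log units; beyond the scatter). The 2-methylphenyl group does not keep the advantage of the 4-methylphenyl group, as it gives a 2.1-fold higher number from compound 2 to compound 4 (0.32 log units; beyond the scatter) against the 4-fluorophenyl group, a step beyond the scatter, and a 1.9-fold higher number from compound 1 to compound 4 (0.28 log units; within the scatter) against the 2-fluorophenyl group, a step within it. Replacing fluoro with methyl therefore has no single effect, and its outcome depends on where on the ring the change is made: the same change on two cores in this assay, a 4.0-fold lower number (0.60 log units; beyond the scatter) from compound 2 to compound 3 and a 1.9-fold higher number (0.28 log units; within the scatter) from compound 1 to compound 4, 7.7-fold (0.89 log units) apart, beyond the scatter of two such steps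

As far as these compounds go, whether methoxy, chloro, an amine or a carboxylic acid on this phenyl ring, or a longer chain such as ethyl in place of methyl, would match compound 3 stays open. These numbers, all from one cell read-out, also do not say why the position of the methyl counts.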